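The source may report more compounds than this note shows. Statements on the series, on what has been measured and on what is new or still open speak of the compounds shown alone.

Going by the values given here, in a functional assay on A549 cells (Homo sapiens) for inhibition, read by MTT assay, with a stated time of 72 h (a lower number here means a stronger inhibitor, a higher number a weaker inhibitor), compound 2 `CN(C(=O)NC(=O)c1ccc([N+](=O)[O-])cc1)c1nc(C(F)(F)F)c(C(=O)N/N=C/c2cccc(C(F)(F)F)c2)s1` gives 5.42 ug/mL, the lowest of the two numbers so far, with compound 1 as its nearest neighbour. Compound 1 `CN(C(=O)NC(=O)c1ccc(F)c(F)c1)c1nc(C(F)(F)F)c(C(=O)N/N=C/c2cccc(C(F)(F)F)c2)s1` gives 6.52 ug/mL, and the step is a 1.2-fold lower number from compound 1 to compound 2 (0.08 log units; within the scatter). Compound 3 `CN(C(=O)NC(=O)c1cccc(C(F)(F)F)c1)c1nc(C(F)(F)F)c(C(=O)N/N=C/c2cccc(C(F)(F)F)c2)s1` carries 3-(trifluoromethyl)phenyl in place of 4-nitrophenyl on a carbonyl carbon. Among the compounds with values here, the only measured step at this carbonyl carbon, a 1.2-fold lower number from compound 1 to compound 2 (0.08 log units; within the scatter), lay within the scatter, so a further exchange of the aryl group there is expected to move this assay little, if at all. Compound 3 is therefore expected to give 5.5 ug/mL, within 2.7 ug/mL to 11 ug/mL. This corresponds to an expected 1.0-fold higher number from compound 2 to compound 3 (0.01 log units; within the scatter).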

Compound 3, half-maximal inhibitory concentration: 8.16 ug/mL
For compound 3 the middle estimate is 1.5-fold (0.17 log units) below the measured one; the range from low to high includes it.
By their numbers in this assay, from the lowest: compounds 2, 1 and 3 (each within the scatter of the next).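

In this assay the steps of a 1.5-fold higher number from compound 2 to compound 3 (0.18 log units; within the scatter) and a 1.3-fold higher number from compound 1 to compound 3 (0.10 log units; within the scatter) both stay within the scatter, so 3-(trifluoromethyl)phenyl, 4-nitrophenyl and 3,4-difluorophenyl cannot be ranked on this carbonyl carbon. Exchanging 4-nitrophenyl, with 2 hydrogen-bond acceptors, for 3-(trifluoromethyl)phenyl, with 0, leaves the number within the scatter. No supporting data bear on this result.

Still open, as far as these compounds go, is whether a non-aryl group, such as an amine, a carboxylic acid or a longer chain, would move the number beyond the scatter at this carbonyl carbon. The compounds shown also leave open how changes elsewhere on the shared core would read.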